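The compounds below may be only part of what the source reports. "The series", "measured", "known", "first", "only" and "open" are said of these compounds alone.

Measured compounds: compound 1 `COC(=O)C[C@@H]1Cc2ccccc2[C@H](CN2CCCCC2)O1` gives 510 nM in an assay on membranes from brain for displacement of a labelled ligand from Sigma non-opioid intracellular receptor 1 (Cavia porcellus), read by scintillation counting, with a stated time of 2 h; on this read-out higher numbers stand for weaker inhibition and lower numbers for stronger inhibition; compound 2 `COC(=O)C[C@@H]1Cc2ccccc2[C@H](CN2CCC(c3ccccc3)CC2)O1` gives 673 nM in this assay.

Compound 1 has the lower of the two numbers, but the step of a 1.3-fold higher number from compound 1 to compound 2 (0.12 log units; within the scatter) lies within the scatter, so the two cannot be ranked. Compound 3 `COC(=O)C[C@@H]1Cc2ccccc2[C@H](CCN2CCCC2)O1` differs from compound 1 by (pyrrolidin-1-yl)methyl in place of piperidin-1-yl on a saturated chain carbon bound to a saturated ring carbon. Among the measured compounds shown here, no measured step touches this part of the structure; the one step measured concerns a phenyl on a ring carbon and is itself within the scatter. For the measured compounds named here, with no bearing step, the expected step is a 1.1-fold lower number from compound 1 to compound 3 (0.05 log units; within the scatter). Compound 3 is therefore estimated at 450 nM, between 150 nM and 1400 nM.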

Compound 3, inhibition constant: > 1000 nM
Compound 3: a limit, no number (the forecaster's own chance of this, stated with the estimate: 3%); middle value at least 2.2-fold (0.34 log units) from the limit.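

Compound 3 is the first change shown to the amine side chain itself; the only earlier step concerned a phenyl on a ring carbon. Compound 3 is reported as a limit, not a number: the limit of > 1000 nM in this assay, at which 1 of the 3 values shown sits. The step is an at least 1.9-fold higher number from compound 1 to compound 3 (0.29 log units; that floor lies within the scatter), so this swap of (piperidin-1-yl)methyl for 2-(pyrrolidin-1-yl)ethyl cannot be firmly ranked, and it alters ring size and chain length together.

The compounds shown leave open which of these two changes matters, and a 2-(piperidin-1-yl)ethyl group would separate them. As far as these compounds go, how a longer chain or a primary amine would read here also stays open.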